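Adding One Methyl to the Dihydroxyphenyl Ring

A few compounds are considered here, and "the series" means these few. Any claim that something is new, unique, unknown or untested is made for them only; others in the source may bear on it.

In a functional assay on MCF7 cells (Homo sapiens) for inhibition, read by MTT assay, with a stated time of 72 h (a lower number here means that less compound is needed, a higher number that more compound is needed for the effect), compound 1 `CC1(C)CCC[C@]2(C)[C@@H](Cc3ccc(O)cc3O)[C@](C)(O)CC[C@@H]12` gives 11900 nM. Compound 2 `CC1(C)CCC[C@]2(C)[C@@H](Cc3c(O)cccc3O)[C@](C)(O)CC[C@@H]12` gives 16000 nM, so these two share the low end of the three values. Compound 3 `CC1(C)CCC[C@]2(C)[C@@H](Cc3cc(O)ccc3O)[C@](C)(O)CC[C@@H]12` stands apart at 50000 nM.

Compound 4 `Cc1cc(O)cc(O)c1C[C@@H]1[C@@]2(C)CCCC(C)(C)[C@@H]2CC[C@@]1(C)O` keeps the core of compound 1 and changes one thing: methyl in place of hydrogen on an aromatic carbon. The new methyl stands ortho to a large group and meta to two hydroxy groups.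

Within the data shown here, no measured step adds a methyl, so the guidance is indirect. Among the measured compounds shown here, the only evidence comes from moving a hydroxy group around the same ring. One such move gave a 1.3-fold higher number from compound 1 to compound 2 (0.13 log units; within the scatter), while another gave a 4.2-fold higher number from compound 1 to compound 3 (0.62 log units; beyond the scatter), and a 3.1-fold higher number from compound 2 to compound 3 (0.49 log units; beyond the scatter) was similarly modest. Ring changes in this small series have therefore shifted the number only slightly or modestly.

The expected result is a 1.1-fold higher number from compound 1 to compound 4 (0.04 log units; within the scatter), a step not expected to pass the scatter, in either direction. For compound 4 the estimated value is 13000 nM, with an expected range of 5000 nM to 35000 nM.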

Compound 4, half-maximal effective concentration: 11300 nM
Compound 4: the middle estimate sits 1.2-fold (0.06 log units) above what was measured; low and high end bracket the measured number.
By their numbers in this assay, from the lowest: compounds 4, 1 and 2 (each within the scatter of the next); then compound 3.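

In this assay, methyl in place of hydrogen gives a 1.1-fold lower number from compound 1 to compound 4 (0.02 log units; within the scatter), so this aromatic carbon, ortho to a large group and meta to two hydroxy groups, can carry a methyl without a change that stands out from the scatter. The earlier compounds shown here showed only what happens when a hydroxy group moves around the ring, and some of those moves went beyond the scatter; this step shows instead that the ring can gain a small group with the number unchanged within the scatter. No measurement here gives a reason for this result.

On these data alone, whether this same aromatic carbon would accept something other than methyl, such as an ethyl group, an amine or a carboxylic acid, remains open. This single step also cannot tell how a methyl would behave on the other carbons of the ring.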